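The compounds below may be only part of what the source reports. "The series", "measured", "known", "first", "only" and "open" are said of these compounds alone.

Measured so far:
Compound 1 `COc1cc(-n2cnc3ccc(-c4ccc([N+](=O)[O-])cc4)cc32)cc(OC)c1OC`: in a functional assay on SGC-7901 cells (Homo sapiens) for antiproliferative activity, read by MTT assay, with a stated time of 72 h (on this read-out higher numbers stand for weaker inhibition and lower numbers for stronger inhibition), compound 1 gives 79 nM.
Compound 2 `COc1cc(-n2cnc3ccc(-c4cccc(O)c4)cc32)cc(OC)c1OC`: in this assay compound 2 gives 53 nM.
Compound 3 `COc1cc(-c2ccc3ncn(-c4cc(OC)c(OC)c(OC)c4)c3c2)cc(OC)c1OC`: in this assay compound 3 gives only > 10000 nM, which is a limit of the assay and not a number.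

Compound 2 holds the lowest of the two numbers, with compound 1 nearest; the step of a 1.5-fold lower number from compound 1 to compound 2 (0.17 log units; within the scatter) is within the scatter. The value of compound 3 is a limit (the limit of > 10000 nM in this assay, at which 1 of the 3 values shown sits).

Compound 4 `COc1cccc(-c2ccc3ncn(-c4cc(OC)c(OC)c(OC)c4)c3c2)c1` differs from compound 2 by methyl in place of hydrogen on an oxygen on an aromatic ring. Within the data shown here, no measured step changes the substituent on this oxygen; the only measured step, a 1.5-fold lower number from compound 1 to compound 2 (0.17 log units; within the scatter), exchanges the whole aryl group and bears on this change only loosely. A step within the scatter is therefore expected in this assay, in either direction. Compound 4 is estimated at 80 nM, with a range from 25 nM to 300 nM. This means an expected step of a 1.5-fold higher number from compound 2 to compound 4 (0.18 log units; within the scatter).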

Compound 4, half-maximal inhibitory concentration: 3310 nM
For compound 4 the middle estimate is 41-fold (1.62 log units) below the measured one; the whole stated range lies below it.
By their numbers in this assay, from the lowest: compounds 2 and 1 (each within the scatter of the next); then compound 4. At a limit, above all of these: compound 3.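

In this assay the oxygen substituent on this aryl group matters: methyl in place of hydrogen gives a 62-fold higher number from compound 2 to compound 4 (1.80 log units; beyond the scatter) as a large loss, although the earlier exchange of whole aryl groups stayed within the scatter. The 3-methoxyphenyl group also falls away from 4-nitrophenyl, with a 42-fold higher number from compound 1 to compound 4 (1.62 log units; beyond the scatter) on the same read-out. Nothing shown accounts for the size of these steps.

As far as these compounds go, whether other replacements of the hydroxy, such as an amine or a carboxylic acid, keep the low numbers remains open. So does the effect of a longer chain, such as ethyl, on the oxygen.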